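The source may report more compounds than this note shows. Statements on the series, on what has been measured and on what is new or still open speak of the compounds shown alone.

Compound 1 `C[C@H](NC(=O)C(=O)NCCC1CCCC1)C(=O)N[C@@H](CC(=O)O)C(=O)COc1c(F)c(F)cc(F)c1F` and compound 2 `C[C@H](NC(=O)C(=O)NCC1CCCCC1)C(=O)N[C@@H](CC(=O)O)C(=O)COc1c(F)c(F)cc(F)c1F` share one core and differ only in the group on a saturated chain carbon bound to an amide-type nitrogen. In a functional assay on Jurkat cells (Homo sapiens) (on this read-out lower numbers stand for stronger inhibition and higher numbers for weaker inhibition), compound 1 gives 11 nM, and compound 2 gives 19 nM. Compound 2 thus carries the higher of the two numbers seen so far, yet the step of a 1.7-fold higher number from compound 1 to compound 2 (0.24 log units; within the scatter) is within the scatter, so the two compounds cannot be told apart on these data.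

Compound 3 `C[C@H](NC(=O)C(=O)NCc1cccc(F)c1)C(=O)N[C@@H](CC(=O)O)C(=O)COc1c(F)c(F)cc(F)c1F` changes the same position again: 3-fluorophenyl in place of cyclohexyl on a saturated chain carbon bound to an amide-type nitrogen. Within the data shown here, the one measured step swapped one saturated ring for another and barely moved the read-out; it does not directly cover the change from a saturated ring to an aromatic one, so the evidence for the new step is thin. With no step beyond the scatter seen at this position, the expectation is again a small one, and the estimate is that the step of a 1.3-fold lower number from compound 2 to compound 3 (0.10 log units; within the scatter) stays within the scatter. Compound 3 is therefore expected to give about 15 nM, between 5 nM and 50 nM.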

Compound 3, half-maximal inhibitory concentration: 106 nM
Compound 3: the middle estimate sits 7.1-fold (0.85 log units) below what was measured; the measured number lies above the stated range.
By their numbers in this assay, from the lowest: compounds 1 and 2 (each within the scatter of the next); then compound 3.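

The choice of group at this position does matter in this assay. Swapping one saturated ring for another left compounds 1 and 2 within the scatter of each other, whereas the aromatic 3-fluorophenyl group gives a 5.6-fold higher number from compound 2 to compound 3 (0.75 log units; beyond the scatter) and a 9.6-fold higher number from compound 1 to compound 3 (0.98 log units; beyond the scatter), both beyond the scatter and both toward weaker inhibition. No measurement at hand bears on the reason for this loss.

Two things enter together in this change, an aromatic ring and a fluorine, so it remains open which of them accounts for the step; a plain benzyl group without the fluorine would separate the two. From the compounds shown here alone, it is also open whether a longer chain, such as 2-phenylethyl, would bring an aromatic ring back toward the numbers of compounds 1 and 2.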